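The source may hold more compounds than are shown below. What is called first, only, known or untested is meant among the compounds shown, and "the series" means these compounds.

Measured so far in a functional assay on MCF7 cells (Homo sapiens) for cytotoxicity, read by MTT assay, with a stated time of 72 h; a higher number here means a weaker inhibitor, a lower number a stronger inhibitor:
- compound 1 `CNC(=O)c1cc(Oc2ccc(C(=O)/C=C/c3ccc(Br)cc3)cc2)ccn1`: > 50000 nM
- compound 2 `CNC(=O)c1cc(Oc2ccc(C(=O)/C=C/c3ccc([N+](=O)[O-])cc3)cc2)ccn1`: "not determined" (no result reported)
- compound 3 `CNC(=O)c1cc(Oc2ccc(C(=O)/C=C/c3ccc(F)cc3Cl)cc2)ccn1`: 21100 nM

The entry for compound 1 is a limit of the assay, not a number. Within the data shown here, compound 3, at 21100 nM, holds the only actual number, so it has no numerical comparator.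

The next compound, compound 4 `CNC(=O)c1cc(Oc2ccc(C(=O)/C=C/c3ccc(F)cc3)cc2)ccn1`, differs from compound 3 by hydrogen in place of chloro on an aromatic carbon, giving 4-fluorophenyl in place of 2-chloro-4-fluorophenyl.

Among the measured compounds shown here, one measured step bears on this change: an at least 2.3-fold lower number from compound 1 to compound 3 (0.37 log units; beyond the scatter), where 2-chloro-4-fluorophenyl replaces 4-bromophenyl. That step changes the halogens in more than one place and starts from a limit, so it offers only loose guidance on the chloro alone. Removing the chloro is expected to give up part of that gain, and a small move toward a higher number in this assay is expected: a 1.7-fold higher number from compound 3 to compound 4 (0.22 log units; within the scatter). For compound 4 the estimated value is 35000 nM, with an expected range of 15000 nM to 70000 nM.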

Compound 4, half-maximal inhibitory concentration: 28500 nM
For compound 4 the middle estimate is 1.2-fold (0.09 log units) above the measured one, within the range that was stated.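

In this assay, among these compounds, a 1.4-fold higher number from compound 3 to compound 4 (0.13 log units; within the scatter), so on this aromatic carbon, ortho to a large group, hydrogen and chloro are not told apart, and this is the only step with a number at both ends. With fluoro in place of bromo, the series reads an at least 1.7-fold lower number from compound 1 to compound 4 (0.24 log units; that floor lies within the scatter), a floor that does not by itself separate the two halogens. The starting point of that step is a limit of the assay for compound 1, not a number: the limit of > 50000 nM in this assay, at which 1 of the 4 values shown sits.

On these data alone, the true size of the bromo to fluoro step remains open, as the limit bounds it from one side only. Also open, as far as these compounds go, is whether an amine or a carboxylic acid on that same aromatic carbon would move the number beyond the scatter, where chloro does not.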